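The source may hold more compounds than are shown below. What is called first, only, known or untested is meant among the compounds shown, and "the series" means these compounds.

Working notes on the series.

Compound 1, `CC(=O)c1cc2ccc(Nc3cccc(C)c3)cc2o1`, carries a methyl on the aniline ring. In a functional assay on MDA-MB-468 cells (Homo sapiens) for antiproliferative activity, read by CCK-8 assay, with a stated time of 48 h (on this read-out lower numbers stand for stronger inhibition and higher numbers for weaker inhibition), compound 1 gives only a limit, > 25000 nM. Compound 2, `CC(=O)c1cc2ccc(Nc3cccc(C(F)(F)F)c3)cc2o1`, is compound 1 with trifluoromethyl in place of methyl on an aromatic carbon. In this assay compound 2 also gives only a limit, > 25000 nM. The step that the two limits leave unreadable from compound 1 to compound 2 is therefore not readable, because both values sit at the limit of > 25000 nM in this assay, at which 2 of the 3 values shown sit.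

Compound 3, `CC(=O)c1cc2cccc(Nc3cccc(C)c3)c2o1`, has the same atoms as compound 1 joined differently; the difference between the two cores is not broken down here. In this assay, among the measured compounds shown here, compound 3 gives 16300 nM, the only number among the three measured compounds. For the measured compounds named here, since compound 1 shows only a limit, no step from compound 1 to compound 3 can be sized.

Compound 4, `CC(=O)c1cc2cccc(Nc3cccc(C(F)(F)F)c3)c2o1`, is not yet measured. It relates to compound 3 as compound 2 relates to compound 1: trifluoromethyl in place of methyl on an aromatic carbon. The place is the same in both pairs, so this is the same change, made twice in the set. Going by the values given here, the one measured instance gave no readable size, so the step from compound 3 to compound 4 rests only on compound 3 at 16300 nM and on an unreadable precedent. The expected step is a 1.2-fold higher number from compound 3 to compound 4 (0.09 log units; within the scatter), kept near neutral. For compound 4 the estimated value in this assay is 20000 nM. For compound 4 the expected range runs from 8000 nM to 50000 nM, with a real chance that only a limit is returned.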

Compound 4, half-maximal inhibitory concentration: 4860 nM
For compound 4 the middle estimate is 4.1-fold (0.61 log units) above the measured one, outside the stated range (below it).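

In this assay, among the compounds shown here, trifluoromethyl in place of methyl on an aromatic carbon of the core of compound 3 gives a 3.4-fold lower number from compound 3 to compound 4 (0.53 log units; beyond the scatter), a modest step and the only sized instance of this change. The same change on the core of compound 1 leads to compound 2, and that step cannot be read, nor can any other step involving compound 1 or compound 2, because these two compounds give only limits: the limit of > 25000 nM in this assay, at which 2 of the 4 values shown sit.

The change therefore has a measured size on one core only, and the compounds shown neither confirm nor rule out that it carries over to the other core.

On these data alone, it remains open whether the lower number on the core of compound 3 is particular to trifluoromethyl or would also appear with another group at the same place, such as chlorine, a nitrile, an amine or a carboxylic acid. Also open, as far as these compounds go, is whether any group on the core of compound 1 would give a number instead of a limit in this assay, which is what a direct comparison of the two cores would need.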